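The compounds below may be only part of what the source reports. "The series", "measured", "known", "first", "only" and "open" are said of these compounds alone.

In a functional assay on THP-1 cells (Homo sapiens) for inhibition, read by sulforhodamine B assay, with a stated time of 48 h, tested at 50 uM (a higher number here means more inhibition of growth at the concentration tested, a lower number less inhibition of growth), compound 1 `O=C1C(=O)N(CCCCn2cc(COc3cc(=O)oc4ccccc34)nn2)c2ccccc21` gives 85%. Compound 3 `O=C1C(=O)N(CCCCCn2cc(COc3cc(=O)oc4ccccc34)nn2)c2ccccc21` is a close relative; the difference between the two cores is not broken down here. In this assay compound 3 gives 69%, and of the three measured values that of compound 1 is the highest, with the other two lying beyond the usual scatter from it.

Compound 2 `O=C1C(=O)N(CCCCCn2cc(COc3cc(=O)oc4ccccc34)nn2)c2ccc(F)cc21` differs from compound 3 in one place only, by the change (fluoro in place of hydrogen on an aromatic carbon). In this assay compound 2 gives 63%. The resulting step is a number 6 percentage points lower from compound 3 to compound 2 (within the scatter), so within this pair the fluoro made no difference that can be told from the scatter.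

Compound 4 `O=C1C(=O)N(CCCCn2cc(COc3cc(=O)oc4ccccc34)nn2)c2ccc(F)cc21` has not yet been measured. It stands to compound 1 as compound 2 stands to compound 3, differing by the change (fluoro in place of hydrogen on an aromatic carbon). The place is described in the same words for both pairs, so this is the same change seen once already. Among the measured compounds shown here, since the only measured instance of it, a number 6 percentage points lower from compound 3 to compound 2 (within the scatter), stayed within the scatter, the step from compound 1 to compound 4 is expected to be small as well, estimated as a number 6 percentage points lower from compound 1 to compound 4 (within the scatter). On that basis compound 4 is expected to give about 79% in this assay, with the estimate most likely lying between 65% and 90%.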

Compound 4, percent growth inhibition at one concentration: 77%
Estimate against measurement, compound 4: 2 percentage points above, and the stated range covers the measured number.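

In this assay, fluoro in place of hydrogen on an aromatic carbon now gives a number 8 percentage points lower from compound 1 to compound 4 (within the scatter), and this second instance cannot be told apart from the first, so the change carries over from one core to the other with no difference that the data can resolve: the same change on two cores in this assay, a number 6 percentage points lower (within the scatter) from compound 3 to compound 2 and a number 8 percentage points lower (within the scatter) from compound 1 to compound 4, 2 percentage points apart, within the scatter of two such steps. For these two pairs, then, the result of the change on one core was a fair guide to its result on the other, and in neither pair can the fluoro compound be separated from its hydrogen parent. This does not show that fluoro is without any effect, since a small real effect could lie hidden within the scatter, nor does it show that the agreement extends beyond these two cores, this one place on the ring, this cell line or this single tested concentration.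

The compounds shown leave open whether a chloro or methoxy group, an amine or a carboxylic acid on the same aromatic carbon would behave as fluoro does. They also leave open whether the fluoro step would hold on a core with a longer chain, and how the compounds would compare across a range of concentrations.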